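Alkoxy chain extension from compound 1 to compound 4

The source may hold more compounds than are shown below. What is called first, only, known or untested is meant among the compounds shown, and "the series" means these compounds.

Compound 1 `CCCOC1=C(CCC)C(=O)/C(=C(O)/C=C/c2ccccc2)C(=O)C1(CCC)CCC` is the reference point among the three measured compounds. In a functional assay on A549 cells (Homo sapiens) for antiproliferative activity, read by sulforhodamine B assay, with a stated time of 3 days (a higher number here means that more compound is needed for the effect, a lower number that less compound is needed), compound 1 gives 1.9 uM, the lowest number of the set, and both other compounds stand apart from it beyond the scatter. Compound 3 `CCCCC1=C(OC)C(CCCC)(CCCC)C(=O)/C(=C(O)\C=C\c2ccccc2)C1=O` gives 6.4 uM in this assay and is the nearest to compound 1. Compound 2 `COC1=C(CC=C(C)C)C(=O)/C(=C(O)/C=C/c2ccccc2)C(=O)C1(CC=C(C)C)CC=C(C)C` gives 10.3 uM in this assay and is the furthest from compound 1. Among the measured compounds shown here, no two measured compounds differ in a single place, so no single step can be read from them; each of compounds 2 and 3 changes several groups at once relative to compound 1. Compound 4 `CCCCOC1=C(CCC)C(=O)/C(=C(O)/C=C/c2ccccc2)C(=O)C1(CCC)CCC` differs from compound 1 by one change: methyl in place of hydrogen on a saturated chain carbon, three bonds along the chain from an oxygen on an unsaturated carbon. For the measured compounds named here, nothing among the measured compounds isolates this change, so the expectation rests on the small size of the change alone. For compound 4 the expected step in this assay is a 1.2-fold higher number from compound 1 to compound 4 (0.06 log units; within the scatter), none beyond the scatter. Compound 4 is estimated at 2.2 uM, within a range of 1 uM to 4.8 uM in this assay.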

Compound 4, concentration for half-maximal effect: 7.1 uM
For compound 4 the middle estimate is 3.2-fold (0.51 log units) below the measured one; the measured number lies above the stated range.
By their numbers in this assay, from the lowest: compound 1; then compounds 3, 4 and 2 (each within the scatter of the next).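

Among the compounds shown here, the first single-place step falls on a saturated chain carbon, three bonds along the chain from an oxygen on an unsaturated carbon: in this assay, propyl to butyl gives a 3.7-fold higher number from compound 1 to compound 4 (0.57 log units; beyond the scatter). This position therefore responds to one added methyl, with a step beyond the scatter, which compounds 2 and 3 could not show since each changes several groups at once. No measurement at hand accounts for this step.

The compounds shown leave open whether the number would keep rising with a pentyl chain at this position or fall with an ethyl chain, and what an amine or a hydroxyl at the chain end would do. They also leave open whether the same extension would have a comparable effect on the propyl groups on the carbons of the core of compound 1.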